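This account rests on a few compounds, and the source may have more. Where it says the series, first, only, none or still open, it means among the compounds named here.

Three compounds of this series have so far been run in a functional assay on the whole organism for inhibition, with Rattus norvegicus as the target, read by paw edema, with a stated time of 4 h, at a dose of 50 mg/kg; on this read-out higher numbers stand for more inhibition at the one dose given (going by the name of the read-out) and lower numbers for less inhibition. Compound 1 `CC(=O)c1c(NNc2ccc([N+](=O)[O-])cc2)cc(C)oc1=O` gives 44.1%, compound 2 `CC(=O)c1c(NNc2cc(C)c3ccccc3n2)cc(C)oc1=O` gives 51%, and compound 3 `Cc1cc2nn(-c3ccccc3)c(C)c2c(=O)o1` gives 43.1%. Compound 3 sits at the lowest of the three numbers, yet its gap to compound 1 and its gap to compound 2 both lie within the scatter, so no ranking among the three can be drawn. Compound 4 `Cc1cc2nn(-c3ccc(Cl)cc3)c(C)c2c(=O)o1` differs from compound 3 by chloro in place of hydrogen on an aromatic carbon. Within the data shown here, no pair of measured compounds differs by this change, so the numbers give no guide to its effect. In this assay a step within the scatter, in no set direction, is expected: a number 1.9 percentage points higher from compound 3 to compound 4 (within the scatter). For compound 4 the expected value in this assay is 45%, within 30% to 60%.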

Compound 4, a percentage reported as inhibition, in the whole organism at one dose (the size of the read-out at that dose, not a potency): 38.2%
Beside the measured number, compound 4's estimate is 6.8 percentage points above it, and the stated range covers the measured number.
By their numbers in this assay, from the lowest: compounds 4, 3, 1 and 2 (each within the scatter of the next, the first and the last beyond it).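

Among these compounds, the first matched pair, with chloro in place of hydrogen on an aromatic carbon para to a large group, gives in this assay a number 4.9 percentage points lower from compound 3 to compound 4 (within the scatter) and so shows no effect of this change that can be told from the scatter. At this position, chloro is compatible with a read-out in the same range as hydrogen. No other data bear on this result. On these data alone, whether an amine, a methoxy group or a carboxylic acid at the same position would give a step beyond the scatter remains open. So does the effect of chloro elsewhere on that ring.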